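This account rests on a few compounds, and the source may have more. Where it says the series, first, only, none or still open, it means among the compounds named here.

Measured compounds:
Compound 1 `CCO[C@]1(c2ccc(OCc3c(-c4c(Cl)cccc4Cl)noc3C3CC3)cc2Cl)C[C@H](c2cccc(C(=O)O)c2)C1` gives 94% in an assay on isolated protein for agonist activity at Bile acid receptor (Homo sapiens), read by FRET; on this read-out lower numbers stand for smaller maximal responses and higher numbers for larger maximal responses.
Compound 2 `CS(=O)(=O)NC(=O)c1ccc([C@@H]2C[C@H]2c2ccc(OCc3c(-c4c(Cl)cccc4Cl)noc3C3CC3)cc2Cl)cc1` gives 94% in this assay.
Compound 3 `O=C(O)c1ccc(C2CC2c2ccc(OCc3c(-c4c(Cl)cccc4Cl)noc3C3CC3)cc2Cl)cn1` gives 101% in this assay.

Within this small set, compound 2 is level with compound 1 at the digits shown, and the two of them share the lowest value of the three. Compound 3 stands nearest in structure to neither yet furthest in number, and even that gap lies within the scatter of this assay. For the measured compounds named here, no pair among the three measured compounds differs in a single place, so no step between measured compounds is available to guide an expectation.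

Compound 4 `CS(=O)(=O)NC(=O)c1ccc(C2CC2c2ccc(OCc3c(-c4c(Cl)cccc4Cl)noc3C3CC3)cc2Cl)cc1` is the compound under consideration. Its relation to compound 2 is as follows: the two compounds have the same atoms and bonds; at least one stereo element is drawn with a configuration in one of them and without one in the other: 2 of 2 stereo elements differ; a stereocentre at a saturated ring carbon is drawn R in compound 2 and without a configuration in compound 4; a stereocentre at a saturated ring carbon is drawn R in compound 2 and without a configuration in compound 4. Nothing enters and nothing leaves; the change concerns only whether the configuration at the two ring stereocentres is drawn.

Because compound 2 reaches 94% in this assay, compound 4 is expected to give a similar maximal response, with a step of a number 2 percentage points lower from compound 2 to compound 4 (within the scatter) that is expected to stay within the usual scatter. The estimate for compound 4 in this assay is 92%, with a range from 80% to 104%.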

Compound 4, largest response reached (reported as efficacy), in percent of the reference or control that the assay uses: 100%
Compound 4: middle estimate off by 8 percentage points, on the low side; the range from low to high includes it.
By their numbers in this assay, from the lowest: compounds 1, 2, 4 and 3 (each within the scatter of the next).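

In this assay, for the compounds shown here, compound 2 and compound 4 form the first pair in this set that differs in one place, and the step between them (a number 6 percentage points higher from compound 2 to compound 4 (within the scatter)) gives the first reading at these two saturated ring carbons. Whether the configuration at the two stereocentres is drawn or left undrawn, this read-out does not separate the two compounds, since repeated measurements of this kind would scatter as widely as the step itself. The one structural difference that can be pointed to in this pair is the following: the fact that one of compounds 2 and 4 is drawn with a defined configuration and the other without, at the place where they differ

From the compounds shown here alone, the drawing of compound 4 does not tell which stereoisomer or mixture of stereoisomers it holds, so the maximal response of any other single configuration remains open in this assay. Also open is how the maximal response would read with an amine in place of the methylsulfonyl group that compound 2 and compound 4 share, since no compound shown carries that change.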